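A few compounds are considered here, and "the series" means these few. Any claim that something is new, unique, unknown or untested is made for them only; others in the source may bear on it.

Compound 1 `CC(C)(C)OC(=O)N1CCC(O[C@H]2CC[C@H](Oc3ccc(S(C)(=O)=O)cn3)CC2)CC1`: 108%
Compound 2 `CC(C)(C)OC(=O)N1CCC(O[C@H]2CC[C@H](Oc3cnc(S(C)(=O)=O)cn3)CC2)CC1`: 110%
Compound 3 `CC1(OC(=O)N2CCC(O[C@H]3CC[C@H](Oc4cnc(S(C)(=O)=O)cn4)CC3)CC2)CC1`: 123%

In a functional assay on isolated protein for agonist activity at Glucose-dependent insulinotropic receptor (Rattus norvegicus), read by HTRF and cAMP accumulation (on this read-out lower numbers stand for smaller maximal responses and higher numbers for larger maximal responses), compound 3 stands highest of the three; compound 2 lies nearest, and the rise was a number 13 percentage points higher from compound 2 to compound 3 (beyond the scatter), while compound 1 lies furthest. The step of a number 2 percentage points higher from compound 1 to compound 2 (within the scatter) did not leave the scatter. Compound 4 `CS(=O)(=O)c1cnc(O[C@H]2CC[C@H](OC3CCN(C(=O)OC4CCOC4)CC3)CC2)cn1` differs from compound 3 by oxolan-3-yl in place of 1-methylcyclopropyl on an oxygen next to a carbonyl group. Among the compounds with values here, the one measured step at this oxygen next to a carbonyl group, a number 13 percentage points higher from compound 2 to compound 3 (beyond the scatter), was modest; no measured step covers the oxolan-3-yl group itself, so the direction is uncertain. A small move in either direction, most likely within the scatter, is expected. Compound 4 is therefore estimated at 113%, between 98% and 128%. That estimate means an expected step of a number 10 percentage points lower from compound 3 to compound 4 (within the scatter).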

Compound 4, largest response reached (Emax), in percent of the reference or control that the assay uses: 109%
Compound 4: middle estimate off by 4 percentage points, on the high side; low and high end bracket the measured number.
By their numbers in this assay, from the lowest: compounds 1, 4 and 2 (each within the scatter of the next); then compound 3.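

In this assay, the oxygen next to a carbonyl group proves sensitive to the ring placed on it: oxolan-3-yl for 1-methylcyclopropyl gives a number 14 percentage points lower from compound 3 to compound 4 (beyond the scatter). Set against tert-butyl, the same group gives a number 1 percentage points lower from compound 2 to compound 4 (within the scatter), so these two groups cannot be told apart here, and only 1-methylcyclopropyl stands clear of the others at this position. Nothing measured here explains the drop. Still open, from the compounds shown here alone, is how a plain cyclopropyl or an oxetan-3-yl group would behave on this oxygen, and whether either would match 1-methylcyclopropyl.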